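The source may hold more compounds than are shown below. What is called first, only, known or untested is meant among the compounds shown, and "the series" means these compounds.

In an ADME assay on HeLa cells (Homo sapiens) for cytotoxicity (a lower number here means that less compound is tolerated, a higher number that more compound is tolerated), compound 1 `CCN(CC)CN1C(=O)/C(=N/NC(=S)Nc2ccccc2)c2cc(Cl)ccc21` gives 13500 nM, and compound 2 `CCN(CC)CN1C(=O)/C(=N/NC(=S)Nc2ccc(Cl)cc2)c2ccccc21` gives 9800 nM. Compound 3 `CCN(CC)CN1C(=O)/C(=N/NC(=S)Nc2ccc(C)cc2)c2cc(Cl)ccc21` gives > 100000 nM, which is a limit of the assay and not a number. Methyl in place of hydrogen on an aromatic carbon produced an at least 7.4-fold higher number from compound 1 to compound 3 (0.86 log units; beyond the scatter), the only measured step here. Compound 4 `CCN(CC)CN1C(=O)/C(=N/NC(=S)Nc2ccc(Cl)cc2)c2cc(Cl)ccc21` is still unmeasured, and its difference from compound 3 is chloro in place of methyl on an aromatic carbon. This change removes that methyl, and compound 2, with the same 4-chlorophenyl, gives 9800 nM. A large drop in this assay is therefore expected, beyond the scatter, and the estimated step is an at least 11-fold lower number from compound 3 to compound 4 (1.04 log units; beyond the scatter). The expected value for compound 4 is 9000 nM, with an estimated range of 2500 nM to 40000 nM.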

Compound 4, half-maximal cytotoxic concentration: 9400 nM
Compound 4: the middle estimate sits 1.0-fold (0.02 log units) below what was measured; the measured number falls inside the stated range.
By their numbers in this assay, from the lowest: compounds 4, 2 and 1 (each within the scatter of the next). At a limit, above all of these: compound 3.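

In this assay, 4-chlorophenyl in place of 4-methylphenyl gives an at least 10-fold lower number from compound 3 to compound 4 (1.02 log units; beyond the scatter) and so brings the number back among the other chloro compounds. Two further steps, each chloro in place of hydrogen, are small: a 1.0-fold lower number from compound 2 to compound 4 (0.02 log units; within the scatter) and a 1.4-fold lower number from compound 1 to compound 4 (0.16 log units; within the scatter) are the readings, so at this position methyl stands apart from both hydrogen and chloro. As far as these compounds go, compound 3 stands at a limit and not at a number, so the full size of its step stays unknown: the limit of > 100000 nM in this assay, at which 1 of the 4 values shown sits. The compounds shown leave open how a methoxy group or an amine would read at this place, and whether methyl would have the same effect on a core without the chloro.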